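The source may report more compounds than this note shows. Statements on the series, on what has been measured and on what is new or still open speak of the compounds shown alone.

Measured in a functional assay on SW1990 cells (Homo sapiens) for cytotoxicity, read by MTT assay, with a stated time of 48 h, in the presence of a further agent that is not named here; on this read-out higher numbers stand for weaker inhibition and lower numbers for stronger inhibition:
compound 1 `O=C(c1ccc2cccc(OCc3ccc(B(O)O)cc3)c2n1)N1CCC(Oc2no[n+]([O-])c2S(=O)(=O)c2ccccc2)CC1` gives 3050 nM
compound 2 `CC1(C)OB(c2ccc(COc3cccc4ccc(C(=O)N5CCC(Oc6no[n+]([O-])c6S(=O)(=O)c6ccccc6)CC5)nc34)cc2)OC1(C)C` gives 2880 nM
compound 3 `O=C(NCCCOc1no[n+]([O-])c1S(=O)(=O)c1ccccc1)c1ccc2cccc(OCc3ccc(B(O)O)cc3)c2n1` gives 1200 nM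

Compound 2 differs from compound 1 by a group of 9 heavy atoms (6 carbon, 1 boron, 2 oxygen; one five-membered non-aromatic ring with 3 hetero atoms) in place of a group of 3 heavy atoms (1 boron, 2 oxygen; no ring), on an aromatic carbon. The resulting step, a 1.1-fold lower number from compound 1 to compound 2 (0.02 log units; within the scatter), leaves the two values indistinguishable. Compound 3 has a different core; the difference between the core of compound 1 and that of compound 3 is not broken down here. Compound 3 stands lowest of the three, beyond the scatter from both others.

Compound 4 `CC1(C)OB(c2ccc(COc3cccc4ccc(C(=O)NCCCOc5no[n+]([O-])c5S(=O)(=O)c5ccccc5)nc34)cc2)OC1(C)C` is not yet measured. It differs from compound 3 by a group of 9 heavy atoms (6 carbon, 1 boron, 2 oxygen; one five-membered non-aromatic ring with 3 hetero atoms) in place of a group of 3 heavy atoms (1 boron, 2 oxygen; no ring), on an aromatic carbon, the same change as between compound 1 and compound 2, at the same place. In this assay the step is expected to be a 1.0-fold lower number from compound 3 to compound 4 (0.02 log units; within the scatter), resting on the earlier step of a 1.1-fold lower number from compound 1 to compound 2 (0.02 log units; within the scatter). Compound 4 is therefore estimated at 1150 nM, with a range from 600 nM to 2300 nM.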

Compound 4, half-maximal inhibitory concentration: 3200 nM
The estimate for compound 4 lay 2.8-fold (0.44 log units) below the measured number, and the stated range ends below it.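

In this assay, putting the group of 9 heavy atoms with its five-membered non-aromatic ring in place of the ringless group of 3 heavy atoms gives a 2.7-fold higher number from compound 3 to compound 4 (0.43 log units; beyond the scatter). The same change therefore does not carry over unchanged from one core to the other, and the two steps differ: the same change on two cores in this assay, a 1.1-fold lower number (0.02 log units; within the scatter) from compound 1 to compound 2 and a 2.7-fold higher number (0.43 log units; beyond the scatter) from compound 3 to compound 4, 2.8-fold (0.45 log units) apart, beyond the scatter of two such steps. With one pair on each core, this shows that the step depends on the core in these two pairs, but not which part of the core matters or how the change would read on a third core.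

Open, on these data alone, is whether a longer chain on the core of compound 3 would keep this step. Also open, as far as these compounds go, is how a carboxylic acid or an amine at the same aromatic carbon would read on either core.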